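Adding a carbamoylmethyl group to a thromboxane receptor antagonist

The compounds below may be only part of what the source reports. "The series", "measured", "known", "first", "only" and "open" are said of these compounds alone.

Compound 1 `O=C(O)CC/C=C\CO[C@H]1C(OCc2ccc(-c3ccccc3)cc2)CC[C@@H]1N1CCCCCC1` carries a seven-membered nitrogen ring on its shared core and a biphenylmethyl ether. In a functional assay for antagonist activity at thromboxane A2 receptor (Rattus norvegicus) (a higher number here means weaker binding, a lower number tighter binding), compound 1 gives 25.1 nM, which is the only single number shown; a second compound has entries but no single value. That second compound, compound 2 `O=C(O)CC/C=C\CO[C@H]1C(OCc2ccc(-c3ccccc3)cc2)CC[C@@H]1N1CCCCC1`, differs in having a six-membered nitrogen ring, and in this assay compound 2 gives 794 nM; 63.1 nM (2 entries), two entries far apart from one another (the several entries of compound 2 in this assay, 794 nM; 63.1 nM (2 entries)), so no firm comparison with compound 1 can be drawn from them.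

Compound 3 `NC(=O)Cc1ccccc1-c1ccc(COC2CC[C@H](N3CCCCCC3)[C@H]2OC/C=C\CCC(=O)O)cc1` is the unmeasured compound. It differs from compound 1 by a single change: carbamoylmethyl in place of hydrogen on an aromatic carbon. Going by the values given here, no measured pair shows what such an addition does, so the expected step from compound 1 to compound 3, a 1.3-fold lower number from compound 1 to compound 3 (0.10 log units; within the scatter), is expected to stay within the usual scatter, perhaps leaning toward tighter binding. On that basis compound 3 is estimated to give 20 nM in this assay, within a range from 4 nM to 100 nM.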

Compound 3, dissociation constant: 158 nM
The estimate for compound 3 lay 7.9-fold (0.90 log units) below the measured number; the measured number lies above the stated range.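

In this assay, carbamoylmethyl in place of hydrogen on an aromatic carbon, ortho to a large group, gives a 6.3-fold higher number from compound 1 to compound 3 (0.80 log units; beyond the scatter). Going by these compounds alone, this is the first measured change at this part of the molecule, and it shows that the position is not indifferent to what is placed there: on this one pair, the added group goes with weaker binding rather than leaving the number unchanged. The size of that step rests on a single comparison and should be read with some care, since entries for one compound in this series can lie far apart, as shown by this spread: the several entries of compound 2 in this assay, 794 nM; 63.1 nM (2 entries)

The compounds shown cannot tell whether the loss belongs to the amide end of the group or would follow from any substituent on that carbon, since none of them carries a simple methyl, a hydroxymethyl or a carboxylic acid there. They also leave open whether carbamoylmethyl would have the same effect at another carbon of that aromatic ring, or on the six-membered nitrogen ring of compound 2.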